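Swapping the side chain on a purine-based peptide ester

A few compounds are considered here, and "the series" means these few. Any claim that something is new, unique, unknown or untested is made for them only; others in the source may bear on it.

Measured compounds:
compound 1 `N=C(N)NCCC[C@H](NC(=O)CN(c1nc(Cl)nc2[nH]cnc12)C1CC1)C(=O)OCc1ccccc1` gives 30.6% in a functional assay on the whole organism (Tail, strain ICR) with Mus musculus as the target, in the tail flick test, with a stated time of 60 min, at a dose of 25 umol/kg by the oral route; a higher number here means a stronger effect of the compound at the dose given, a lower number a weaker effect
compound 2 `CC(C)[C@H](NC(=O)CN(c1ncnc2c1ncn2C1CCCCO1)C1CC1)C(=O)OCc1ccccc1` gives 34.9% in this assay

Among the measured compounds shown here, compound 1 and compound 2 differ in several places at once, so no single step is traced between them; their two values sit within the scatter of each other, and neither can be placed above the other on these numbers. For the measured compounds named here, compound 1 therefore stands on level ground with the only other measured compound.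

Compound 3 `CC(C)C[C@H](NC(=O)CN(c1nc(Cl)nc2[nH]cnc12)C1CC1)C(=O)OCc1ccccc1` keeps the core of compound 1 and changes the side chain: a group of 3 heavy atoms (3 carbon; no ring) in place of a group of 6 heavy atoms (3 carbon, 3 nitrogen; no ring), on a saturated chain carbon, two bonds along the chain from an amide-type nitrogen and a carbonyl carbon. Going by the values given here, no measured pair shows this step directly. Since compound 2, which carries an isopropyl group on that chain carbon, gives 34.9%, the change is expected to move the number little, with no step beyond the scatter in either direction. Compound 3 is estimated to give 33% in this assay, in the range 18% to 48%, meaning an expected step of a number 2.4 percentage points higher from compound 1 to compound 3 (within the scatter).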

Compound 3, a percentage reported as activity, at one dose (the size of the read-out at that dose, not a potency): 27.3%
Beside the measured number, compound 3's estimate is 5.7 percentage points above it; low and high end bracket the measured number.
By their numbers in this assay, from the lowest: compounds 3, 1 and 2 (each within the scatter of the next).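

Among the compounds shown here, this is the first direct look at this position: in this assay, replacing the group of 6 heavy atoms with isopropyl, on a saturated chain carbon, gives a number 3.3 percentage points lower from compound 1 to compound 3 (within the scatter). The two groups therefore cannot be told apart here, even though the group that leaves carries 3 nitrogen atoms and 3 hydrogen-bond donors and isopropyl carries none, so on the core of compound 1 this read-out does not depend on keeping those atoms. No measurement on hand offers an explanation for this result.

On these data alone, whether a small methyl group, a carboxylic acid or a longer chain with a terminal amine at this position would produce a step beyond the scatter remains open. As far as these compounds go, each figure also comes from a single dose, so any difference in potency between compound 1 and compound 3 also remains open.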